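The compounds below may be only part of what the source reports. "The series", "measured", "known", "first", "only" and "open" are said of these compounds alone.

Measured in a functional assay on K562 cells (Homo sapiens) for cytotoxicity, read by trypan blue exclusion, with a stated time of 96 h; a lower number here means a stronger inhibitor, a higher number a weaker inhibitor:
- compound 1 `COC(=O)CNc1cc(NS(=O)(=O)/C=C/c2c(OC)cc(OC)cc2OC)ccc1OC`: 350 nM
- compound 2 `COC(=O)C(C)(C)Nc1cc(NS(=O)(=O)/C=C/c2c(OC)cc(OC)cc2OC)ccc1OC`: 300 nM
- compound 3 `COC(=O)C(Nc1cc(NS(=O)(=O)/C=C/c2c(OC)cc(OC)cc2OC)ccc1OC)c1ccc(Cl)cc1`: 2500 nM

Of these three, compound 3 carries the highest number, at 2500 nM. Compound 4 `COC(=O)C(Nc1cc(NS(=O)(=O)/C=C/c2c(OC)cc(OC)cc2OC)ccc1OC)c1ccc(Br)cc1` differs from it by bromo in place of chloro on an aromatic carbon, with bromo in place of chloro on an aromatic carbon, para to a large group. Within the data shown here, no measured step covers this exchange. The steps that reach compound 3 are a 7.1-fold higher number from compound 1 to compound 3 (0.85 log units; beyond the scatter) and an 8.3-fold higher number from compound 2 to compound 3 (0.92 log units; beyond the scatter), both beyond the scatter, but they bring in the whole 4-chlorophenyl-bearing group rather than change its halogen. a 1.2-fold lower number from compound 1 to compound 2 (0.07 log units; within the scatter) concerns another substituent. No step beyond the scatter is therefore expected in this assay. The estimate is no change at the digits printed from compound 3 to compound 4 (within the scatter). For compound 4 the expected value is 2500 nM, with an estimated range of 1100 nM to 5500 nM.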

Compound 4, half-maximal inhibitory concentration: 1000 nM
Compound 4: the middle estimate sits 2.5-fold (0.40 log units) above what was measured; measured number outside the range, below it.
By their numbers in this assay, from the lowest: compounds 2 and 1 (each within the scatter of the next); then compound 4; then compound 3.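

In this assay the halogen on this ring proves to matter: bromo in place of chloro gives a 2.5-fold lower number from compound 3 to compound 4 (0.40 log units; beyond the scatter), so a change of one atom at this place moves the number beyond the scatter. The gain does not restore the level of the compounds without an aryl group, as a 2.9-fold higher number from compound 1 to compound 4 (0.46 log units; beyond the scatter) and a 3.3-fold higher number from compound 2 to compound 4 (0.52 log units; beyond the scatter) both show. Nothing available accounts for the difference between the two halogens. The compounds shown leave open whether fluoro, iodo or methyl at this place would continue the shift. They also leave open where the plain phenyl group would fall.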